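Swapping a nitrile for two methyls on the amide aryl ring

The source may hold more compounds than are shown below. What is called first, only, known or untested is meant among the compounds shown, and "the series" means these compounds.

Measured compounds:
Compound 1 `Cc1cc(C(=O)NCN2CCC(c3cccc[n+]3[O-])CC2)ccc1F`: 50 nM
Compound 2 `N#Cc1cccc(C(=O)NCN2CCC(c3cccc[n+]3[O-])CC2)c1`: 840 nM

In a functional assay on HEK293 cells for agonist activity at D(4) dopamine receptor (Homo sapiens), read by FLIPR (on this read-out higher numbers stand for an effect only at larger amounts of compound and lower numbers for an effect already at smaller amounts), compound 2 gives 840 nM, the highest number of the two measured compounds, while compound 1 gives 50 nM. Among the measured compounds shown here, the one measured step, a 17-fold higher number from compound 1 to compound 2 (1.23 log units; beyond the scatter), shows that replacing a methyl- and fluorine-bearing ring with a nitrile-bearing ring raised the number a great deal.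

Compound 3 `Cc1cc(C)cc(C(=O)NCN2CCC(c3cccc[n+]3[O-])CC2)c1` has not been measured. Its change from compound 2 is 3,5-dimethylphenyl in place of 3-cyanophenyl on a carbonyl carbon. This removes the nitrile that arrived in the step from compound 1 to compound 2 and puts methyl groups back on the ring, so the step from compound 2 to compound 3 is expected to run in the opposite direction, lowering the number by an amount in the region of an 8.4-fold lower number from compound 2 to compound 3 (0.92 log units; beyond the scatter). The estimate for compound 3 in this assay is therefore 100 nM, expected to fall between 30 nM and 400 nM.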

Compound 3, half-maximal effective concentration: 90 nM
Compound 3: middle estimate off by 1.1-fold (0.05 log units), on the high side; measured number inside the range.
By their numbers in this assay, from the lowest: compounds 1 and 3 (each within the scatter of the next); then compound 2.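

In this assay, the change on the carbonyl carbon now reads in both directions: 3,5-dimethylphenyl in place of 3-cyanophenyl gives a 9.3-fold lower number from compound 2 to compound 3 (0.97 log units; beyond the scatter), so among these compounds the high number belongs to the one ring that carries a nitrile, not to the shared core. The two rings without a nitrile cannot be told apart, with a 1.8-fold higher number from compound 1 to compound 3 (0.26 log units; within the scatter), so 3,5-dimethylphenyl and 4-fluoro-3-methylphenyl serve about equally well here. Nothing measured on these groups accounts for the gap.

The nitrile ring also carries one group where the other two rings carry two, so the nitrile itself and the missing second group remain tangled. A ring with a single methyl, or a methoxy group or chlorine in the nitrile's place, would be needed to separate them.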